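A few compounds are considered here, and "the series" means these few. Any claim that something is new, unique, unknown or untested is made for them only; others in the source may bear on it.

Compound 1 `NC(=O)N1CCN(C(=S)SCc2cn(Cc3ccccc3F)nn2)CC1` was tested in a functional assay on SMMC-7721 cells (Homo sapiens) for cytotoxicity, read by MTT assay, with a stated time of 72 h (a higher number here means a weaker inhibitor, a lower number a stronger inhibitor), and compound 1 gave only a limit there, > 128000 nM. Its two measured relatives share that outcome. Compound 2 `CCNC(=O)N1CCN(C(=S)SCc2cn(Cc3ccccc3F)nn2)CC1` also reached only the limit of this assay, > 128000 nM. Compound 3 `CC(C)(C)NC(=O)N1CCN(C(=S)SCc2cn(Cc3ccccc3F)nn2)CC1` likewise stopped at a limit, > 128000 nM. The steps among them are therefore unreadable: a step that the two limits leave unreadable from compound 1 to compound 2, a step that the two limits leave unreadable from compound 1 to compound 3 and a step that the two limits leave unreadable from compound 2 to compound 3, all three resting at the limit of > 128000 nM in this assay, at which 3 of the 3 values shown sit.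

Compound 4 `COc1ccc(Cn2cc(CSC(=S)N3CCN(C(N)=O)CC3)nn2)cc1` differs from compound 1 in another part of the molecule: 4-methoxyphenyl in place of 2-fluorophenyl on a saturated chain carbon bound to an aromatic nitrogen. Within the data shown here, none of the measured steps touches the benzyl group, so none bears directly on this change, and all three measured values are limits, which gives no anchor for its size or direction. Since every measured relative of compound 1 sits at the limit, compound 4 is expected to stay there as well, with a step that the limit leaves unreadable from compound 1 to compound 4. Compound 4 is thus estimated at 250000 nM in this assay, within a range from 80000 nM to 800000 nM, most likely reported again only as a limit.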

Compound 4, half-maximal inhibitory concentration: > 128000 nM
Compound 4: no number, only a limit; the forecaster's own chance of this, stated with the estimate: 80%; the middle value is on the limit's open side.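

In this assay compound 4 gave only a limit, > 128000 nM. The step from compound 1 to compound 4 therefore cannot be read, since both values are limits: the limit of > 128000 nM in this assay, at which 4 of the 4 values shown sit.

The compounds shown leave open whether changing the benzyl group or the group on the amide-type nitrogen alters cytotoxicity at all.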